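The compounds below may be only part of what the source reports. "The series", "measured", "known", "first", "only" and "open" are said of these compounds alone.

Compound 1, `CCC[C@H](CCn1cncn1)c1ccccc1`, is the reference point. For the measured compounds named here, in an ADME assay on RD cells (Homo sapiens) for cytotoxicity, read by MTT assay, with a stated time of 3 days (on this read-out lower numbers stand for higher toxicity in this test and higher numbers for lower toxicity in this test), compound 1 gives 63.1 ug/mL, the highest of the two numbers measured so far. Its nearest neighbour is compound 2, `CCC[C@H](CCn1cncn1)c1ccc(OC)cc1`, which in this assay gives 59.3 ug/mL; the step from the one to the other is a 1.1-fold lower number from compound 1 to compound 2 (0.03 log units; within the scatter), and it comes from a methoxy in place of hydrogen on an aromatic carbon. The next compound, compound 3, `Cc1ccc(C[C@H](CCn2cncn2)c2ccccc2)cc1`, differs from compound 1 in another way: 4-methylphenyl in place of ethyl on a saturated chain carbon, two bonds along the chain from an aromatic carbon. Going by the values given here, no measured step touches this part of the molecule, so the single step recorded, a 1.1-fold lower number from compound 1 to compound 2 (0.03 log units; within the scatter), bears on it only indirectly, by showing that the shared core tolerated one change without moving beyond the scatter. The change here is larger, since a 4-methylphenyl replaces an ethyl, and a somewhat lower number is thought plausible, although a result within the scatter of compound 1 is also expected to be possible. For compound 3 in this assay the estimate is 45 ug/mL, with a range from 20 ug/mL to 100 ug/mL. This estimate means an expected step of a 1.4-fold lower number from compound 1 to compound 3 (0.15 log units; within the scatter).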

Compound 3, half-maximal cytotoxic concentration: 37.8 ug/mL
Compound 3: the middle estimate sits 1.2-fold (0.08 log units) above what was measured, within the range that was stated.
By their numbers in this assay, from the lowest: compounds 3, 2 and 1 (each within the scatter of the next).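

For the compounds shown here, on a saturated chain carbon, two bonds along the chain from an aromatic carbon, a place that no earlier step had touched, 4-methylphenyl in place of ethyl gives in this assay a 1.7-fold lower number from compound 1 to compound 3 (0.22 log units; within the scatter) and so stays close to compound 1. The change takes 2 heavy atoms out and puts 7 heavy atoms in, with one six-membered aromatic ring of carbon only, so this place is now shown to accept a much larger all-carbon group without a step beyond the scatter, which the methoxy on the aromatic carbon could not show. No measured evidence is available to explain why the read-out stays within the scatter at this place.

The compounds shown leave open whether an unsubstituted phenyl, a longer chain, an amine or a carboxylic acid at this same carbon would also stay within the scatter of compound 1. They also leave open how methoxy on the aromatic carbon and 4-methylphenyl on the chain would read together in one molecule in this assay as a pair of changes.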